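Removing the ring methyl: compound 2 to compound 3

The compounds below may be only part of what the source reports. "The series", "measured", "known", "first", "only" and "open" are said of these compounds alone.

Measured compounds:
- compound 1, `CSc1ccc(-c2cn(C)nc2[C@@H]2CCC(F)(F)C[C@H]2C(=O)NCC#N)cc1`, 41 nM
- compound 2, `Cn1cc(-c2ccc(S(C)(=O)=O)cc2)c([C@@H]2CCC(F)(F)C[C@H]2C(=O)NC2(C#N)CC2)n1`, 35 nM

Of the compounds shown here, two have been measured in a functional assay on Bone element (Oryctolagus cuniculus) for inhibition; on this read-out lower numbers stand for stronger inhibition and higher numbers for weaker inhibition. Compound 1 gives 41 nM, and compound 2 gives 35 nM; compound 2 has the lowest of the two numbers, while the gap to compound 1 lies within the scatter, so neither can be called stronger. Compound 3, `CS(=O)(=O)c1ccc(-c2c[nH]nc2[C@@H]2CCC(F)(F)C[C@H]2C(=O)NC2(C#N)CC2)cc1`, has not yet been measured. It differs from compound 2 in one place: hydrogen in place of methyl on an aromatic nitrogen. Among the measured compounds shown here, no measured pair shows this change, so no step size is known for it. The expectation for compound 3 is a step of a 1.4-fold higher number from compound 2 to compound 3 (0.15 log units; within the scatter) that stays within the usual scatter, with no direction that can be supported by the measured pair. Compound 3 is therefore estimated at 50 nM, with a range from 15 nM to 170 nM.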

Compound 3, half-maximal inhibitory concentration: 120 nM
Compound 3: the middle estimate sits 2.4-fold (0.38 log units) below what was measured; measured number inside the range.
By their numbers in this assay, from the lowest: compounds 2 and 1 (each within the scatter of the next); then compound 3.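

In this assay, hydrogen in place of methyl on the aromatic nitrogen gives a 3.4-fold higher number from compound 2 to compound 3 (0.54 log units; beyond the scatter) and so moves the read-out beyond the scatter. Among the compounds shown here, this is the first single change with a readable step, as compounds 1 and 2 differ in more than one place and offered none; it shows that, in this pair, inhibition weakens when the methyl is removed from this nitrogen. Nothing available bears on why this step occurs.

Only methyl and hydrogen are shown on this nitrogen, so it remains open how an ethyl, a cyclopropyl or a 2-hydroxyethyl group would read out here. On these data alone, it also remains open whether the same change would give a step of similar size on compound 1, which carries a different amide group and a methylthio group on its phenyl ring.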